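The source may report more compounds than this note shows. Statements on the series, on what has been measured and on what is new or still open speak of the compounds shown alone.

In an ADME assay on the whole organism (strain 129/SvEvBrd x C57BL/6) for metabolic stability, with Mus musculus as the target (a lower number here means that the compound disappears faster, a higher number that the compound lasts longer), compound 1 `CC(F)(F)c1nc([C@@H](O)[C@H](O)[C@H](O)CO)c[nH]1` gives 1 h. Compound 2 `OC[C@@H](O)[C@@H](O)[C@H](O)c1c[nH]c(-c2cocn2)n1` gives 1.2 h, which places it level with compound 1 within the scatter. Compound 3 `OC[C@@H](O)[C@@H](O)[C@H](O)c1c[nH]c(-c2ncc[nH]2)n1` keeps the shared core of compound 2 and changes one group on an aromatic carbon, between two ring nitrogen atoms: 1H-imidazol-2-yl in place of 1,3-oxazol-4-yl on an aromatic carbon. Among the measured compounds shown here, only one measured step bears on this change, the exchange of 1,1-difluoroethyl for 1,3-oxazol-4-yl on an aromatic carbon: a 1.2-fold higher number from compound 1 to compound 2 (0.08 log units; within the scatter). For the measured compounds named here, that step lies within the scatter, and no measured compound yet carries 1H-imidazol-2-yl. With so little evidence, no shift beyond the scatter is expected in this assay, and no direction can be favoured with confidence. The expected step is a 1.1-fold lower number from compound 2 to compound 3 (0.04 log units; within the scatter). Compound 3 is estimated at 1.1 h, with an expected range from 0.6 h to 2 h.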

Compound 3, half-life: 3.2 h
The estimate for compound 3 lay 2.9-fold (0.46 log units) below the measured number; the whole stated range lies below it.
By their numbers in this assay, from the lowest: compounds 1 and 2 (each within the scatter of the next); then compound 3.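

At this position, between two ring nitrogen atoms, the group can shift the half-life beyond the scatter in this assay: 1H-imidazol-2-yl in place of 1,3-oxazol-4-yl gives a 2.7-fold higher number from compound 2 to compound 3 (0.43 log units; beyond the scatter) and the same group in place of 1,1-difluoroethyl gives a 3.2-fold higher number from compound 1 to compound 3 (0.51 log units; beyond the scatter) on the shared core. The first of these exchanges keeps a five-membered aromatic ring with 2 hetero atoms and the same number of heavy atoms, yet nitrogen replaces oxygen and the entering ring carries a hydrogen-bond donor that the leaving ring lacks. Nothing available explains why the compound lasts longer.

As far as these compounds go, whether the hydrogen-bond donor is what matters remains open, since the two rings also differ in their atoms and in how they are attached. From the compounds shown here alone, it also remains open how other groups at this position, such as an amine, a carboxylic acid or a 1H-pyrrol-2-yl ring, would behave.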